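Diaryl ether thiosemicarbazones: nitro for methyl step

This account rests on a few compounds, and the source may have more. Where it says the series, first, only, none or still open, it means among the compounds named here.

Compound 2 `Cc1ccc(Oc2ccc(/C=N/NC(=S)Nc3ccc(Cl)cc3)cc2)cc1` in a physicochemical assay for lipophilicity, in phosphate buffer, measured as octanol-water partition, with a stated time of 24 h (on this read-out higher numbers stand for higher lipophilicity and lower numbers for lower lipophilicity), gives 5.97, the lowest of the three numbers. Compound 3 `Cc1ccc(Oc2ccc(/C=N/NC(=S)Nc3ccc(Br)cc3)cc2)cc1` gives 6.17; the step of a number 0.20 log units higher from compound 2 to compound 3 (within the scatter) stays within the scatter. Within the data shown here, compound 1 `S=C(N/N=C/c1ccc(Oc2ccc3ccccc3c2)cc1)Nc1ccc(Cl)cc1` gives 6.96; the step of a number 0.99 log units lower from compound 1 to compound 2 (beyond the scatter) is the one change at the group on the ether oxygen. Compound 4 `O=[N+]([O-])c1ccc(Oc2ccc(/C=N/NC(=S)Nc3ccc(Cl)cc3)cc2)cc1` differs from compound 2 in nitro in place of methyl on an aromatic carbon. Among the measured compounds shown here, no measured step exchanges methyl for nitro on this ring, so the two steps bear only by analogy: the halogen swap stayed within the scatter, the aryl swap was modest. The step expected here is a number 0.77 log units lower from compound 2 to compound 4 (beyond the scatter), downward. Compound 4 is estimated at 5.2, within 4.7 to 5.7.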

Compound 4, partition coefficient: 5.52
The estimate for compound 4 lay 0.32 log units below the measured number; low and high end bracket the measured number.
By their numbers in this assay, from the lowest: compound 4; then compounds 2 and 3 (each within the scatter of the next); then compound 1.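

In this assay, the change from 4-methylphenyl to 4-nitrophenyl gives a number 0.45 log units lower from compound 2 to compound 4 (beyond the scatter), so a substituent swap on this ring alone, not only replacement of the whole aryl group on the ether oxygen, moves the number beyond the scatter. Replacing naphthalen-2-yl with 4-nitrophenyl gives a number 1.44 log units lower from compound 1 to compound 4 (beyond the scatter), the largest step shown in this series. Nothing on hand accounts for these steps. Going by these compounds, whether an amine or a carboxylic acid on this ring would give a step in the same direction stays open. Also open, on these data alone, is whether the nitro step holds in the bromo compound 3.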